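A Shortened Chain on a Weakly Cytotoxic Purine Scaffold

This account rests on a few compounds, and the source may have more. Where it says the series, first, only, none or still open, it means among the compounds named here.

Of the compounds shown here, two have been tested so far in a functional assay on MCF7 cells (Homo sapiens) for cytotoxicity; a lower number here means that less compound is needed, a higher number that more compound is needed for the effect. Compound 1, `COc1cc(Cc2nc3c(N)ncnc3n2CCCCO)cc(OC)c1OC`, gives 76900000 nM. Compound 2, `CCCCCCn1c(Cc2cc(OC)c(OC)c(OC)c2)nc2c(N)nc(F)nc21`, gives 112000000 nM. Of the two numbers, that of compound 2 is the one at the top, yet compound 1 sits within the usual scatter of it, so the two cannot be told apart, and both lie at concentrations so high that neither shows meaningful cytotoxicity. For the measured compounds named here, compound 1 and compound 2 differ in more than one place, so no single step connects them.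

Compound 3, `C#CCCn1c(Cc2cc(OC)c(OC)c(OC)c2)nc2c(N)nc(F)nc21`, has not yet been measured in this assay. It differs from compound 2 in one place: ethynyl in place of butyl on a saturated chain carbon, two bonds along the chain from an aromatic nitrogen. The butyl group gives way to an ethynyl, shortening the chain on the aromatic nitrogen.

Going by the values given here, with only two near-inactive compounds in hand, there is nothing to suggest that this change should move the number beyond the usual scatter, so the step from compound 2 to compound 3 is expected to be a 1.1-fold lower number from compound 2 to compound 3 (0.05 log units; within the scatter), essentially none. Compound 3 is therefore estimated at 100000000 nM, within a range from 35000000 nM to 300000000 nM.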

Compound 3, half-maximal effective concentration: 286000000 nM
The estimate for compound 3 lay 2.9-fold (0.46 log units) below the measured number, within the range that was stated.
By their numbers in this assay, from the lowest: compounds 1 and 2 (each within the scatter of the next); then compound 3.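

In this assay the position proves sensitive to what it carries: ethynyl in place of butyl on a saturated chain carbon, two bonds along the chain from an aromatic nitrogen, gives a 2.6-fold higher number from compound 2 to compound 3 (0.41 log units; beyond the scatter), a modest step, and the first in this series that can be read beyond the scatter. The earlier compounds shown here could not show this, since they differ in more than one place; here the hexyl to but-3-yn-1-yl change moves the number towards needing more compound, not less, and all three compounds remain at very high concentrations. Nothing measured on these compounds accounts for the shift.

This single step cannot separate the loss of two chain carbons from the arrival of the triple bond, and a plain butyl chain in place of the but-3-yn-1-yl would be needed to part the two. Also open, as far as these compounds go, is whether the direction of the step holds for a chain longer than hexyl, or whether an amine or a carboxylic acid in place of the ethynyl would move the number at all.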